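This account rests on a few compounds, and the source may have more. Where it says the series, first, only, none or still open, it means among the compounds named here.

Measured so far in a functional assay (brain) for inhibition, with Rattus norvegicus as the target; on this read-out lower numbers stand for stronger inhibition and higher numbers for weaker inhibition:
Compound 1 `Cc1c(C)c2c(c(C)c1O)C(CNC(C)C)C(C)(C)O2` gives 1400 nM
Compound 2 `Cc1c(C)c2c(c(C)c1O)C(CN(C)C)C(C)(C)O2` gives 700 nM

Compound 2 and compound 1 lie within the scatter of each other, so these two numbers cannot be ranked. For the measured compounds named here, the only measured step is a 2.0-fold lower number from compound 1 to compound 2 (0.30 log units; within the scatter), with dimethylamino in place of isopropylamino.

Compound 3 `Cc1c(C)c2c(c(C)c1O)C(CO)C(C)(C)O2` has not yet been measured. It comes from compound 2 through a different change, (hydroxy in place of dimethylamino on a saturated chain carbon bound to a saturated ring carbon), which puts hydroxy in place of dimethylamino on a saturated chain carbon bound to a saturated ring carbon.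

The measured step bears on this only loosely. Going by the values given here, it swaps one amino group for another, whereas here the nitrogen leaves altogether, and no measured pair shows such a loss. The data therefore favour no direction, and the expected change is a 1.1-fold higher number from compound 2 to compound 3 (0.06 log units; within the scatter), a step not expected to stand clear of the scatter. For compound 3 the estimated value is 800 nM, with an expected range from 200 nM to 3500 nM, kept wide for lack of a closer precedent.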

Compound 3, half-maximal inhibitory concentration: 2600 nM
Beside the measured number, compound 3's estimate is 3.3-fold (0.51 log units) below it, and the stated range covers the measured number.
By their numbers in this assay, from the lowest: compounds 2, 1 and 3 (each within the scatter of the next, the first and the last beyond it).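

In this assay, for the compounds shown here, replacing the amine on this side chain with hydroxy gives the first step here that stands clear of the scatter, though only modestly: (a 3.7-fold higher number from compound 2 to compound 3 (0.57 log units; beyond the scatter)). Measured from the other amine, the same kind of swap gives (a 1.9-fold higher number from compound 1 to compound 3 (0.27 log units; within the scatter)), so compound 1 and compound 3 cannot be ranked, and the loss of nitrogen stands out only in the comparison with dimethylamino. No measurement offered alongside these numbers accounts for the difference between the two comparisons.

As far as these compounds go, with only dimethylamino, isopropylamino and hydroxy to compare at this place, it remains open how a primary amine, a methoxy group or a carboxylic acid would read on the same saturated chain carbon. From the compounds shown here alone, it is also open whether a cyclic amine such as pyrrolidine would fall nearer to compound 2 or to compound 3, and whether a longer chain carrying the dimethylamino group would keep the number of compound 2.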